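Amide nitrogen substituents on the shared core: step to compound 4

The compounds below may be only part of what the source reports. "The series", "measured", "known", "first", "only" and "open" are said of these compounds alone.

The series holds the core constant and varies the group on an amide-type nitrogen. In an assay for inhibition of 6-phosphofructo-2-kinase/fructose-2,6-bisphosphatase 3 (Homo sapiens), read by ADP-Glo, with a stated time of 2 h (a lower number here means a stronger inhibitor, a higher number a weaker inhibitor), compound 1 `Cn1cc(NC(=O)c2ccncc2Nc2cc(-c3ccc4ccn(C)c4c3)c3nccnc3c2)cn1` gives 33 nM, compound 2 `Cn1cc(CNC(=O)c2ccncc2Nc2cc(-c3ccc4ccn(C)c4c3)c3nccnc3c2)cn1` gives 159 nM, and compound 3 `CC(=O)N1CCC(NC(=O)c2ccncc2Nc2cc(-c3ccc4ccn(C)c4c3)c3nccnc3c2)CC1` gives 18 nM. Compound 3 has the lowest of the three numbers, but its gap to compound 1 is within the scatter (a 1.8-fold lower number from compound 1 to compound 3 (0.26 log units; within the scatter)), so the two cannot be ordered; only compound 2 is clearly set apart (a 4.8-fold higher number from compound 1 to compound 2 (0.68 log units; beyond the scatter), an 8.8-fold lower number from compound 2 to compound 3 (0.95 log units; beyond the scatter)).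

Compound 4 `CC(=O)N1CCCC(NC(=O)c2ccncc2Nc2cc(-c3ccc4ccn(C)c4c3)c3nccnc3c2)C1` differs from compound 3 by 1-acetylpiperidin-3-yl in place of 1-acetylpiperidin-4-yl on an amide-type nitrogen. Among the compounds with values here, no measured step moves a ring attachment point in this way; the three measured steps all swap one group for another on the same amide-type nitrogen, and only the insertion of a methylene between nitrogen and ring moved the number beyond the scatter. A ring-position shift with the same atoms is therefore expected to give a step in this assay of a 1.7-fold higher number from compound 3 to compound 4 (0.22 log units; within the scatter), within the scatter or close to it. Compound 4 is estimated at 30 nM, with a range from 10 nM to 100 nM.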

Compound 4, half-maximal inhibitory concentration: 11 nM
Beside the measured number, compound 4's estimate is 2.7-fold (0.44 log units) above it, and the stated range covers the measured number.
By their numbers in this assay, from the lowest: compounds 4, 3 and 1 (each within the scatter of the next, the first and the last beyond it); then compound 2.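

In this assay, moving the ring attachment from 1-acetylpiperidin-4-yl to 1-acetylpiperidin-3-yl on the amide-type nitrogen gives a 1.6-fold lower number from compound 3 to compound 4 (0.21 log units; within the scatter), so the two attachment points cannot be ordered and this position tolerates the shift without a resolved change. The new group does separate itself from the 1-methyl-1H-pyrazol-4-yl group, with a 3.0-fold lower number from compound 1 to compound 4 (0.48 log units; beyond the scatter), a separation that compound 3 did not reach, and it widens the gap to the (1-methyl-1H-pyrazol-4-yl)methyl group, with a 14-fold lower number from compound 2 to compound 4 (1.16 log units; beyond the scatter). No supporting data accompany these numbers to account for any of these steps.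

Going by these compounds, the role of the acetyl remains open, since both piperidine compounds carry it and neither a free amine nor a longer acyl chain such as propionyl stands in its place. On these data alone, the effect of ring size is also open, as a 1-acetylpyrrolidin-3-yl group would test it.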